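Replacing a thiourea end with a glycine ester urea

This account rests on a few compounds, and the source may have more. Where it says the series, first, only, none or still open, it means among the compounds named here.

Of the compounds shown here, two have been measured in an assay (Cavia porcellus) for inhibition of Polyunsaturated fatty acid 5-lipoxygenase (Homo sapiens); a higher number here means a weaker inhibitor, a lower number a stronger inhibitor. Compound 1 `NC(=O)N(O)CC1=Cc2cc(OCCCc3ccccc3)ccc2OC1` gives 160 nM. Compound 2 `NC(=S)N(O)CC1=Cc2cc(Oc3ccccc3)ccc2OC1` gives 200 nM. The two numbers lie within the usual scatter of each other, so on the numbers shown compound 2 sits level with compound 1, the only other measured compound, and neither can be called stronger or weaker.

Compound 3 `CCOC(=O)CNC(=O)N(O)CC1=Cc2cc(Oc3ccccc3)ccc2OC1` has not yet been measured. It differs from compound 2 by a group of 9 heavy atoms (5 carbon, 1 nitrogen, 3 oxygen; no ring) in place of a group of 3 heavy atoms (1 carbon, 1 nitrogen, 1 sulfur; no ring), on an amine nitrogen. Going by the values given here, no step between two measured compounds isolates this change, so the size of the step in this assay cannot be read directly from the data.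

The expectation is that the step from compound 2 to compound 3 is a 2.0-fold higher number from compound 2 to compound 3 (0.30 log units; within the scatter), a mild move toward weaker inhibition, with a real chance that it stays inside the scatter. On that basis compound 3 is estimated to give 400 nM in this assay, with a range from 150 nM to 1200 nM.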

Compound 3, half-maximal inhibitory concentration: 74 nM
For compound 3 the middle estimate is 5.4-fold (0.73 log units) above the measured one; the measured number lies below the stated range.
By their numbers in this assay, from the lowest: compound 3; then compounds 1 and 2 (each within the scatter of the next).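

In this assay, replacing the thiourea end with the ((ethoxycarbonyl)methyl)carbamoyl group gives a 2.7-fold lower number from compound 2 to compound 3 (0.43 log units; beyond the scatter) and so shows that this position, on an amine nitrogen whose other neighbours are oxygen and a saturated chain carbon, can carry a group of 9 heavy atoms without losing inhibition. Going by these compounds alone, this is also the first step that changes only one place, as compounds 1 and 2 differ in more than one and could say nothing about this end alone. Nothing available explains the gain, and the step cannot separate the exchange of sulfur for oxygen from the addition of the ester chain.

A plain urea end on the core of compound 2 would separate those two parts of the change. On these data alone, what the ester contributes also remains open, and a carboxylic acid in place of the ethyl ester, or a longer chain between the amine nitrogen and the ester, would each alter just one feature of the new group.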